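Swapping the aryl on the piperazine nitrogen of compound 1

A few compounds are considered here, and "the series" means these few. Any claim that something is new, unique, unknown or untested is made for them only; others in the source may bear on it.

The measured compounds are:
Compound 1, `Nc1scc(CN2CCN(c3cccc(C(F)(F)F)c3)CC2)c1C(=O)c1ccc(Cl)cc1`, which in a functional assay on CHO cells with adenosine receptor A1 (Homo sapiens) as the target, read by cAMP accumulation and immunoassay, with a stated time of 6 min, tested at 0.01 uM (a lower number here means a stronger effect, a higher number a weaker effect of the compound at the concentration tested), gives -8.2%.
Compound 2, `Nc1scc(CN2CCN(c3c(F)cccc3F)CC2)c1C(=O)c1cccc(C(F)(F)F)c1`, which in this assay gives 2.1%.

Compound 1 stands lowest of the two numbers; the nearest, compound 2, sits higher by a gap that is beyond the usual scatter. Both numbers, however, lie close to zero, so neither compound shows much effect at the tested concentration.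

Compound 3, `Nc1scc(CN2CCN(c3ccc(F)c(F)c3)CC2)c1C(=O)c1ccc(Cl)cc1`, has not been measured in this assay. It differs from compound 1 in one place: 3,4-difluorophenyl in place of 3-(trifluoromethyl)phenyl on an amine nitrogen in a ring. For the measured compounds named here, no step between two measured compounds of this kind is known, so the size of the step can only be guessed.

Compound 3 is expected to stay near the null level, with a step of a number 8.2 percentage points higher from compound 1 to compound 3 (within the scatter) that is not expected to exceed the scatter. The estimate for compound 3 is 0%, within a range from -12% to 12%.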

Compound 3, a percentage reported as activity, at one concentration (the size of the read-out at that concentration, not a potency): -3.2%
Compound 3: middle estimate off by 3.2 percentage points, on the high side; measured number inside the range.
By their numbers in this assay, from the lowest: compounds 1, 3 and 2 (each within the scatter of the next, the first and the last beyond it).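

In this assay, for the compounds shown here, placing 3,4-difluorophenyl in place of 3-(trifluoromethyl)phenyl on the amine nitrogen in the ring gives a number 5 percentage points higher from compound 1 to compound 3 (within the scatter), the first step that can be read at this position. The entering group has fewer heavy atoms than the group that leaves, and this exchange of one fluorinated phenyl for another leaves the number within the scatter, with both compounds close to zero at the single concentration tested. Nothing at hand bears on the reason for this result.

From the compounds shown here alone, it remains open whether a different group on this nitrogen, such as a phenyl carrying a methoxy or a nitrile, or a plain alkyl chain in place of the aryl, would move the number clearly away from zero. The compounds shown also leave open whether the same exchange would produce a visible step at a higher concentration.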